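Polyamine-tailed chalcones on PC-3: shortening the tail

A few compounds are considered here, and "the series" means these few. Any claim that something is new, unique, unknown or untested is made for them only; others in the source may bear on it.

Measured so far:
- compound 1 `COc1ccc(/C=C/C(=O)c2cc(OC)c(OC)c(OC)c2)cc1OCCCC(=O)NCCCNCCCCNCCN`: 31800 nM
- compound 2 `COc1cc(C(=O)/C=C/c2ccc(OCCCC(=O)NCCCCNCCCN)cc2)cc(OC)c1OC`: 79300 nM

In a functional assay on PC-3 cells (Homo sapiens) for antiproliferative activity, read by MTT assay, with a stated time of 48 h (a higher number here means a weaker inhibitor, a lower number a stronger inhibitor), compound 1 gives 31800 nM and holds the lowest of the two numbers. Its nearest neighbour, compound 2, gives 79300 nM in this assay, a gap that lies beyond the scatter. For the measured compounds named here, the two share the tail-bearing ether chain and the amide link, but differ in how the trimethoxyphenyl and the tail-bearing ring sit about the enone, and in the polyamine tail itself, so no single-point step connects them.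

Compound 3 `COc1ccc(/C=C/C(=O)c2cc(OC)c(OC)c(OC)c2)cc1OCCCC(=O)NCCCCNCCCN` keeps the core of compound 1 and takes the shorter tail of compound 2: the change is ((3-aminopropyl)amino)methyl in place of (4-((2-aminoethyl)amino)butyl)amino on a saturated chain carbon, three bonds along the chain from an amide-type nitrogen. Going by the values given here, with no measured single-point step to lean on, the direction is read only from the two values shown, which put the longer-tailed arrangement ahead. A weakening of modest size, close to the scatter, is expected from compound 1 to compound 3, a 1.4-fold higher number from compound 1 to compound 3 (0.15 log units; within the scatter). Compound 3 is estimated at 45000 nM in this assay, within 18000 nM to 110000 nM.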

Compound 3, half-maximal inhibitory concentration in the PC-3 assay: 51000 nM
For compound 3 the middle estimate is 1.1-fold (0.05 log units) below the measured one; the measured number falls inside the stated range.
By their numbers in the PC-3 assay, from the lowest: compounds 1, 3 and 2 (each within the scatter of the next, the first and the last beyond it).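

At this position, on a saturated chain carbon, three bonds along the chain from an amide-type nitrogen, the series now has its first single-point step: with the core of compound 1 held fixed, ((3-aminopropyl)amino)methyl in place of (4-((2-aminoethyl)amino)butyl)amino reads in the PC-3 assay (compound 1 gives 31800 nM and compound 3 gives 51000 nM) as a 1.6-fold higher number from compound 1 to compound 3 (0.21 log units; within the scatter). The same exchange in a physicochemical assay for lipophilicity, read by spectrophotometry, measured as octanol-water partition, tested at 300 uM; a lower number here means a more polar compound, a higher number a more lipophilic compound (compound 1 gives -1.57 and compound 3 gives -1.28) reads a number 0.29 log units higher from compound 1 to compound 3 (within the scatter), so in neither assay does this shortening of the tail separate the two compounds beyond the scatter. Nothing available accounts for either step, and the two readings cannot be tied together by any measured cause.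

Open, from the compounds shown here alone, is whether a tail cut back further at this position, such as a single primary amine, or one ending in a carboxylic acid, would give a step beyond the scatter in the PC-3 assay. Also open, going by these compounds, is whether this exchange reads the same on a core without the methoxy group on the tail-bearing ring, the feature that sets compound 2 apart from compound 3.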